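The source may report more compounds than this note shows. Statements on the series, on what has been measured and on what is new or still open speak of the compounds shown alone.

Working notes on the series around a shared core. In an assay on membranes from brain (Cavia porcellus) for binding affinity to Sigma non-opioid intracellular receptor 1 (Homo sapiens), read by radioligand binding (a lower number here means a stronger inhibitor, a higher number a weaker inhibitor), compound 1 `Cc1cccc(NC(=N)Nc2cccc3ccccc23)c1` gives 75 nM. In this assay compound 2 `CCc1cccc(NC(=N)N(C)c2cccc3ccccc23)c1` gives 1000 nM. In this assay compound 3 `Cc1cccc(N(C)C(=N)Nc2cccc3ccccc23)c1` gives 1860 nM. Among the measured compounds shown here, compound 3 stands at the highest of the three numbers; its gap to compound 2 lies within the scatter, so no order between those two is claimed, while the step of a 25-fold higher number from compound 1 to compound 3 (1.39 log units; beyond the scatter) lies beyond the scatter and is the one marked change among the measured pairs, methyl in place of hydrogen on a nitrogen on an aromatic ring.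

Compound 4 `CN(C(=N)Nc1cccc2ccccc12)c1cccc([N+](=O)[O-])c1` differs from compound 3 by nitro in place of methyl on an aromatic carbon, meta to a large group. For the measured compounds named here, no measured step exchanges a methyl for a nitro on the ring, so nothing bears directly on it. The step of a 25-fold higher number from compound 1 to compound 3 (1.39 log units; beyond the scatter) concerns the methyl on the nitrogen, which compound 4 keeps exactly as in compound 3, and so gives no direction for this change. Compound 4 is therefore expected to sit near compound 3 in this assay, with a 1.2-fold lower number from compound 3 to compound 4 (0.09 log units; within the scatter) expected to stay within the scatter. The estimate for compound 4 in this assay is 1500 nM, expected between 400 nM and 6000 nM.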

Compound 4, half-maximal inhibitory concentration: 6260 nM
Estimate against measurement, compound 4: 4.2-fold (0.62 log units) below; measured number outside the range, above it.
By their numbers in this assay, from the lowest: compound 1; then compounds 2 and 3 (each within the scatter of the next); then compound 4.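

With the methyl on the nitrogen held as in compound 3, the aromatic carbon meta to a large group proves responsive in this assay: nitro in place of methyl there gives a 3.4-fold higher number from compound 3 to compound 4 (0.53 log units; beyond the scatter) and places compound 4 at the high end of the numbers in the series. Among the compounds shown here, this is the first measured change at this ring position, and it lies beyond the scatter, so the position is not neutral for this exchange, though the step remains modest beside the large 25-fold higher number from compound 1 to compound 3 (1.39 log units; beyond the scatter) on the nitrogen. The exchange replaces one heavy atom with three and brings in two hydrogen-bond acceptors, and no information here accounts for the higher number.

The compounds shown leave open whether the nitro for methyl exchange would carry the same direction and size with hydrogen on that nitrogen, as in compound 1, since the step is seen only with the methyl present. They also leave open whether the higher number is particular to nitro or would recur with an amine, a methoxy group or a chlorine on the same aromatic carbon.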